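The compounds below may be only part of what the source reports. "The series", "measured", "known", "first", "only" and "open" are said of these compounds alone.

Values from a functional assay on OVCAR-3 cells (Homo sapiens) for cytotoxicity, read by MTT assay, with a stated time of 6 days (a lower number here means a stronger inhibitor, a higher number a weaker inhibitor), for the series so far:
- Compound 1 `COc1ccccc1NC(=O)SC[C@H](NC(C)=O)C(=O)O` gives > 200000 nM as a limit
- Compound 2 `CC(=O)N[C@@H](CSC(=O)Nc1ccccc1Cl)C(=O)O` gives > 200000 nM as a limit
- Compound 3 `COc1ccc(NC(=O)SC[C@H](NC(C)=O)C(=O)O)cc1` gives > 200000 nM as a limit

Compound 3 stands at > 200000 nM and this is a limit, not a number. The same holds across the series, with the limit of > 200000 nM in this assay, at which 3 of the 3 values shown sit, as the whole of the evidence so far.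

Compound 4 `CC(=O)N[C@@H](CSC(=O)Nc1ccc(I)cc1)C(=O)O` is not yet measured. It differs from compound 3 by a single change, (iodo in place of methoxy on an aromatic carbon), with iodo in place of methoxy on an aromatic carbon, para to a large group.

Going by the values given here, the closest measured change is chloro in place of methoxy on an aromatic carbon, seen in a step that the two limits leave unreadable from compound 1 to compound 2 as the only step available. That step has no readable size, so it sets no scale and no direction for the new change. All three measured compounds carry a limit and none gives a number to start from.

The estimated change is a number no higher from compound 3 to compound 4 (the limit leaves the size open) and no step beyond the usual scatter is expected in this assay for this swap.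

For compound 4 the estimate is 200000 nM with an expected range from 70000 nM to 300000 nM and another report as a limit is the likeliest outcome.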

Compound 4, half-maximal inhibitory concentration: > 200000 nM
Compound 4: only a limit was reported (the forecaster's own chance of this, stated with the estimate: 75%); the middle value lies on the limit itself.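

In this assay compound 4 gives > 200000 nM, which is a limit and not a number. The step from compound 3 to compound 4 therefore cannot be read, and the series stays at a single limit: the limit of > 200000 nM in this assay, at which 4 of the 4 values shown sit.

The compounds shown leave open whether methoxy, chloro and iodo on the aromatic ring differ at all in this assay.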